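Adding a third methoxy to a bromo-hydroxystilbene

The compounds below may be only part of what the source reports. "The series", "measured", "known", "first", "only" and "open" are said of these compounds alone.

Measured compounds:
compound 1, `COc1ccc(/C=C/c2cc(OC)c(OC)c(OC)c2)c(O)c1`, 35 nM
compound 2, `COc1cc(/C=C/c2ccc(OC)cc2O)cc(OC)c1`, 800 nM
compound 3, `COc1cc(/C=C/c2cc(Br)ccc2O)cc(OC)c1`, 3300 nM

Three stilbenes have been tested in a functional assay on MGC-803 cells (Homo sapiens) for antiproliferative activity, read by MTT assay; a higher number here means a weaker inhibitor, a lower number a stronger inhibitor. Compound 1 gives 35 nM and compound 2 gives 800 nM; the two differ by one change, (methoxy in place of hydrogen on an aromatic carbon), and that change makes a large step, a 23-fold lower number from compound 2 to compound 1 (1.36 log units; beyond the scatter). Compound 3 gives 3300 nM, the highest number of the three; how its core differs from that of compound 2 is not broken down here.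

Compound 4, `COc1cc(/C=C/c2cc(Br)ccc2O)cc(OC)c1OC`, has not yet been measured in this assay. It differs from compound 3 by methoxy in place of hydrogen on an aromatic carbon. This is the same change, at the same kind of place, as the one from compound 2 to compound 1, and among the compounds shown it occurs two times in all, once measured and once not.

For the measured compounds named here, the expectation for compound 4 rests on the step of a 23-fold lower number from compound 2 to compound 1 (1.36 log units; beyond the scatter), the only measured instance of the change, tempered by the fact that it was seen on a different core. Accordingly the step expected is an 11-fold lower number from compound 3 to compound 4 (1.04 log units; beyond the scatter), large but somewhat smaller than the one measured. Compound 4 is therefore expected to give about 300 nM in this assay, most likely between 80 nM and 1200 nM.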

Compound 4, half-maximal inhibitory concentration: 4500 nM
The estimate for compound 4 lay 15-fold (1.18 log units) below the measured number; measured number outside the range, above it.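

In this assay the methoxy that enters compound 4 in place of hydrogen, ortho to two methoxy groups and para to a large group, gives a 1.4-fold higher number from compound 3 to compound 4 (0.13 log units; within the scatter) and so leaves no measurable change on this core, unlike the large gain seen with the same change on the core of compound 2. The change therefore does not carry over unaltered from one core to the other, and the difference between the two steps is real rather than noise: the same change on two cores in this assay, a 23-fold lower number (1.36 log units; beyond the scatter) from compound 2 to compound 1 and a 1.4-fold higher number (0.13 log units; within the scatter) from compound 3 to compound 4, 31-fold (1.49 log units) apart, beyond the scatter of two such steps. For the compounds shown here, this does not show which difference between the two cores is responsible or why the steps part, and with only one pair on each core it gives no general rule for how the methoxy behaves on any other core.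

The compounds shown leave open whether the large step belongs to the core of compound 2 alone or would also appear on cores carrying a group other than bromo, such as chloro, an amine or a carboxylic acid in the place the bromine holds. They also leave open whether a longer chain such as ethoxy, entering where the new methoxy stands, would behave any differently on either core.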